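Adding one methoxy to a pyrazin-2-yl group

The compounds below may be only part of what the source reports. "The series", "measured", "known", "first", "only" and "open" are said of these compounds alone.

In an ADME assay on MDCKII-LE cells (Canis lupus familiaris) for permeability (a higher number here means that the compound crosses the layer faster, a lower number that the compound crosses the layer more slowly), compound 1 `Cc1ccc(NC(=O)c2cc(Oc3cnc(C(=O)N(C)C)cn3)c3cc(C)oc3c2)nc1` gives 21.5 10^-6 cm/s and compound 2 `Cc1cc2c(Oc3cnc(C(=O)N(C)C)cn3)cc(C(=O)Nc3cnccn3)cc2o1` gives 30 10^-6 cm/s. These two compounds differ only in the group on an amide-type nitrogen, where pyrazin-2-yl takes the place of 5-methylpyridin-2-yl. That swap is a 1.4-fold higher number from compound 1 to compound 2 (0.14 log units; within the scatter), so compound 2 stands level with compound 1. Compound 3 `COc1cnc(NC(=O)c2cc(Oc3cnc(C(=O)N(C)C)cn3)c3cc(C)oc3c2)cn1` differs from compound 2 by one change: methoxy in place of hydrogen on an aromatic carbon. Pyrazin-2-yl thus becomes 5-methoxypyrazin-2-yl. Within the data shown here, the single measured step touches this same amide group and stays within the scatter, but it does not test a methoxy. The data therefore point in no firm direction, and no shift beyond the scatter is expected in this assay. The estimated step is a 1.2-fold lower number from compound 2 to compound 3 (0.06 log units; within the scatter). For compound 3, the expected value is 26 10^-6 cm/s, within an estimated range from 13 10^-6 cm/s to 45 10^-6 cm/s.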

Compound 3, apparent permeability: 15.8 10^-6 cm/s
Compound 3: the middle estimate sits 1.6-fold (0.22 log units) above what was measured; measured number inside the range.
By their numbers in this assay, from the lowest: compounds 3, 1 and 2 (each within the scatter of the next).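

In this assay, turning pyrazin-2-yl into 5-methoxypyrazin-2-yl gives a 1.9-fold lower number from compound 2 to compound 3 (0.28 log units; within the scatter) and so shows that this aromatic carbon, para to a large group, can carry a methoxy without a step beyond the scatter. Set against the 5-methylpyridin-2-yl group, the new group gives a 1.4-fold lower number from compound 1 to compound 3 (0.13 log units; within the scatter) and thus also stays within the scatter, leaving all three amide groups shown level in this assay. Nothing available here explains these results.

From the compounds shown here alone, whether an ethoxy, an amine or a carboxylic acid at this same carbon would also stay within the scatter remains open. Also open, going by these compounds, is what a methoxy would do on the 5-methylpyridin-2-yl group, where the ring differs from the one tested here.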